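The compounds below may be only part of what the source reports. "The series", "measured", "known", "first", "only" and "open" are said of these compounds alone.

Of the compounds shown here, three have so far been measured in a functional assay on ECa-109 cells (Homo sapiens) for antiproliferative activity, read by MTT assay, with a stated time of 72 h; a lower number here means a stronger inhibitor, a higher number a weaker inhibitor.

Compound 1 `CCCSc1nc(N/N=C(\C)c2ccc(OC)cc2)c2nnn(Cc3ccccc3)c2n1` gives > 64000 nM, which is a limit of the assay rather than a number.
Compound 2 `CCCSc1nc(N/N=C/c2cc(OC)c(OC)c(OC)c2)c2nnn(Cc3ccccc3)c2n1` gives 4060 nM.
Compound 3 `CCCSc1nc(N/N=C/c2c[nH]c3ccccc23)c2nnn(Cc3ccccc3)c2n1` gives 8690 nM.

Of the two values that are real numbers, compound 3 holds the higher one, so it is the weaker inhibitor of that pair; the number for compound 2 lies below it by a gap beyond the usual scatter. Compound 1 stands apart, sitting at the limit of > 64000 nM in this assay, at which 1 of the 3 values shown sits.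

Compound 4 `CCCSc1nc(N/N=C/c2ccc([N+](=O)[O-])cc2)c2nnn(Cc3ccccc3)c2n1` keeps the whole core of compound 3 and changes a single group: 4-nitrophenyl in place of 1H-indol-3-yl on a carbon with a double bond to nitrogen. Going by the values given here, no step between two measured compounds resembles this swap, so nothing measured fixes its size. What the numbers do show is that compound 2 and compound 3 sit fairly close together in this assay, while compound 1 sits at the limit. On that footing a small step is expected, a 1.3-fold lower number from compound 3 to compound 4 (0.13 log units; within the scatter), with no firm direction. Compound 4 is therefore estimated at 6500 nM, between 2000 nM and 25000 nM.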

Compound 4, half-maximal inhibitory concentration: 6640 nM
Compound 4: the middle estimate sits 1.0-fold (0.01 log units) below what was measured; the measured number falls inside the stated range.
By their numbers in this assay, from the lowest: compounds 2, 4 and 3 (each within the scatter of the next, the first and the last beyond it). At a limit, above all of these: compound 1.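

Going by these compounds alone, this is the first step measured at this place on the carbon with a double bond to nitrogen, and in this assay putting 4-nitrophenyl in place of 1H-indol-3-yl gives a 1.3-fold lower number from compound 3 to compound 4 (0.12 log units; within the scatter). The two groups have the same count of heavy atoms but differ in their rings, and the hydrogen-bond donor of 1H-indol-3-yl is gone while 4-nitrophenyl brings two hydrogen-bond acceptors, yet this pair of compounds cannot be told apart in this assay. Nothing measured here explains this match in their numbers.

One pair cannot show whether this holds for other groups at this place. A 4-aminophenyl or a 4-carboxyphenyl group could behave quite differently, and the compounds shown do not settle that.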